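Pyrimidin-5-yl replaces furan-2-yl at the assay limit

This account rests on a few compounds, and the source may have more. Where it says the series, first, only, none or still open, it means among the compounds named here.

Compound 1 `CCN(c1ccc(C#N)c(Cl)c1)c1cc(-n2cnc3ccccc32)ccc1C`: 8160 nM
Compound 2 `CCN(c1ccc(C#N)c(Cl)c1)c1cc(-c2ccco2)ccc1C`: > 30000 nM (a limit)

Both compounds were tested in a functional assay on PC-3 cells (Homo sapiens) for antiproliferative activity, read by CCK-8 assay, with a stated time of 6 days; on this read-out lower numbers stand for stronger inhibition and higher numbers for weaker inhibition. Compound 2 gives > 30000 nM, which is a limit of the assay and not a number. Its place on the scale is the limit of > 30000 nM in this assay, at which 1 of the 2 values shown sits. The next compound, compound 3 `CCN(c1ccc(C#N)c(Cl)c1)c1cc(-c2cncnc2)ccc1C`, keeps the shared core and changes one group, with pyrimidin-5-yl in place of furan-2-yl on an aromatic carbon.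

Among the compounds with values here, only one measured step bears on this site, namely an at least 3.6-fold higher number from compound 1 to compound 2 (0.56 log units; beyond the scatter). That step lies beyond the scatter, so changing this group can shift the read-out. As far as these compounds go, its true size is unknown, however, and neither compound carries pyrimidin-5-yl. Compound 2 also offers only a limit as a starting point, so any measurable result for compound 3 must be a lower number. The expected change is small, and it is estimated as an at least 1.3-fold lower number from compound 2 to compound 3 (0.13 log units; that floor lies within the scatter). A result reaching the limit again would be no surprise. For compound 3 the estimated value is 22000 nM, with an expected range from 8000 nM to 30000 nM.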

Compound 3, half-maximal inhibitory concentration: > 30000 nM
Compound 3: only a limit was reported (the forecaster's own chance of this, stated with the estimate: 45%); middle value at least 1.3-fold (0.13 log units) from the limit.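

In this assay, compound 3 gives > 30000 nM, which is a limit of the assay and not a number, so a second replacement at this position, a six-membered aromatic ring with 2 hetero atoms instead of a five-membered one, also fails to give a measurable value. Pyrimidin-5-yl in place of 1H-benzimidazol-1-yl gives an at least 3.6-fold higher number from compound 1 to compound 3 (0.56 log units; beyond the scatter), which means that two different groups on this aromatic carbon now fall short of the 1H-benzimidazol-1-yl of compound 1. The step between compound 2 and compound 3 cannot be read, since both values are limits, and compound 1 remains the only one of the three with a measurable number: the limit of > 30000 nM in this assay, at which 2 of the 3 values shown sit.

As far as these compounds go, how far compound 2 and compound 3 actually lie past the limit stays unknown, so the furan and pyrimidine rings cannot be ranked against each other. Also open, from the compounds shown here alone, is whether a different group at this position, such as an amine or a carboxylic acid, would give a lower number than compound 1, at 8160 nM.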